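This account rests on a few compounds, and the source may have more. Where it says the series, first, only, none or still open, it means among the compounds named here.

In an assay on HEK293 cells for inhibition of transient receptor potential cation channel subfamily V member 1 (Homo sapiens), read by FLIPR, at pH 5.5 (on this read-out higher numbers stand for weaker inhibition and lower numbers for stronger inhibition), compound 2 `Cc1cnnc(N2CCN(C(=O)Nc3ccc(C(C)C)cc3)CC2)c1` gives 20300 nM. Compound 1 `Cc1cc(N2CCN(C(=O)Nc3ccc(C(C)C)cc3)CC2)nnc1Cl` carries chloro in place of hydrogen on an aromatic carbon; in this assay its value of > 10000 nM is a limit of the assay, not a number (the limit of > 10000 nM in this assay, at which 1 of the 3 values shown sits). The step that the limit leaves unreadable from compound 2 to compound 1 therefore has no readable size. Compound 3 `Cc1ccnnc1N1CCN(C(=O)Nc2ccc(C(C)(C)C)cc2)[C@H](C)C1` gives 15.2 nM in this assay; how its core differs from the core of compound 2 is not broken down here. Compound 4 `Cc1cc(Cl)nnc1N1CCN(C(=O)Nc2ccc(C(C)(C)C)cc2)[C@H](C)C1` carries the same kind of change made on compound 3 (chloro in place of hydrogen on an aromatic carbon), though the entering chloro is meta to a methyl group, whereas in compound 1 it is ortho to a methyl group. With no readable size from the measured pair, the expected step of a 1.3-fold higher number from compound 3 to compound 4 (0.12 log units; within the scatter) rests on compound 3 alone at 15.2 nM and is taken as small. Compound 4 is expected to give about 20 nM, between 4 nM and 100 nM.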

Compound 4, half-maximal inhibitory concentration: 67.5 nM
Beside the measured number, compound 4's estimate is 3.4-fold (0.53 log units) below it; the measured number falls inside the stated range.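

In this assay, chloro in place of hydrogen on the core of compound 3 is a 4.4-fold higher number from compound 3 to compound 4 (0.65 log units; beyond the scatter), a modest loss of inhibition on this one core. Compound 1 gives > 10000 nM, which is a limit of the assay and not a number, so the step to it on the other core cannot be read: the limit of > 10000 nM in this assay, at which 1 of the 4 values shown sits. The series therefore offers one readable pair, which does not show whether the change carries the same size from one core to another.

The compounds shown leave open how fluoro, methoxy or an amine at the same place on the core of compound 3 would compare with chloro. They also leave open how chloro would behave on a core where both values can be read.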